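A few compounds are considered here, and "the series" means these few. Any claim that something is new, unique, unknown or untested is made for them only; others in the source may bear on it.

Of the compounds shown here, three built on one shared core have been measured in an assay on HL-60 cells for agonist activity at vitamin D3 receptor (Homo sapiens), read by microscopy, with a stated time of 96 h; on this read-out lower numbers stand for an effect already at smaller amounts and higher numbers for an effect only at larger amounts of compound. Compound 2 `CCN(CC)CCCNC(=O)c1ccc(C(CC)(CC)c2ccc(OCC(=O)C(C)(C)C)c(C)c2)n1CC` gives 22 nM. Compound 3 `CCn1c(C(=O)N(C)CCC#N)ccc1C(CC)(CC)c1ccc(OCC(=O)C(C)(C)C)c(C)c1` gives 9800 nM, the highest of the two numbers recorded, and the step of a 450-fold higher number from compound 2 to compound 3 (2.65 log units; beyond the scatter) sets it well apart. Compound 1 `CCOC(=O)CN(C)C(=O)c1ccc(C(CC)(CC)c2ccc(OCC(=O)C(C)(C)C)c(C)c2)n1CC` reaches only a limit of the assay, > 50000 nM, so that (the limit of > 50000 nM in this assay, at which 1 of the 3 values shown sits). The step of an at least 5.1-fold lower number from compound 1 to compound 3 (0.70 log units; beyond the scatter) therefore rests on that limit, and the step of an at least 2200-fold lower number from compound 1 to compound 2 (3.35 log units; beyond the scatter) likewise.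

Compound 4 `C=CCN(C)C(=O)c1ccc(C(CC)(CC)c2ccc(OCC(=O)C(C)(C)C)c(C)c2)n1CC` differs from compound 3 in that (vinyl in place of cyanomethyl on a saturated chain carbon bound to an amide-type nitrogen). Of the measured steps, only an at least 5.1-fold lower number from compound 1 to compound 3 (0.70 log units; beyond the scatter) changes the group on the same saturated chain carbon, and it is at least modest. The vinyl group that enters carries no hydrogen-bond acceptor, whereas the cyanomethyl that leaves carries one; compound 1, whose ethoxycarbonyl group sits at the limit > 50000 nM, offers the nearest comparison. A modest rise, a 2.6-fold higher number from compound 3 to compound 4 (0.41 log units; beyond the scatter), is expected. Compound 4 is thus estimated at 25000 nM, with a range from 5000 nM to 60000 nM.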

Compound 4, half-maximal effective concentration: 21600 nM
Estimate against measurement, compound 4: 1.2-fold (0.06 log units) above; low and high end bracket the measured number.
By their numbers in this assay, from the lowest: compound 2; then compound 3; then compound 4. At a limit, above all of these: compound 1.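

In this assay, replacing cyanomethyl with vinyl on a saturated chain carbon bound to an amide-type nitrogen removes the hydrogen-bond acceptor of the nitrile, and the number moves only modestly: a 2.2-fold higher number from compound 3 to compound 4 (0.34 log units; beyond the scatter). That change is small beside the exchange of the whole group on the carbonyl carbon, a 980-fold higher number from compound 2 to compound 4 (2.99 log units; beyond the scatter), so neither cyanomethyl nor vinyl comes near the (3-(diethylamino)propyl)amino group of the best compound shown. The step of an at least 2.3-fold lower number from compound 1 to compound 4 (0.36 log units; beyond the scatter) is only a bound, resting on a limit of the assay: the limit of > 50000 nM in this assay, at which 1 of the 4 values shown sits.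

The compounds shown leave open whether the low number depends on the diethylamino group itself or on the amide hydrogen that goes with it. A piperidine or a dimethylamino group on a shorter chain at the same carbonyl carbon would help to separate these.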